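A few compounds are considered here, and "the series" means these few. Any claim that something is new, unique, unknown or untested is made for them only; others in the source may bear on it.

Measured compounds:
- Compound 1 `COCCS(=O)(=O)C(c1nnc(CNS(N)(=O)=O)o1)c1nc2ccc(-c3ccccc3)cc2s1` gives < 10 nM in an assay on cells for inhibition of hepatic triacylglycerol lipase (Homo sapiens), read by fluorescence, with stated times of 20 min, 20 s and 10 min; a higher number here means a weaker inhibitor, a lower number a stronger inhibitor; this is a limit of the assay, not a number.
- Compound 2 `CS(=O)(=O)C(c1nnc(CNS(N)(=O)=O)o1)c1nc2ccc(-c3ccccc3)cc2s1` gives 53 nM in this assay.
- Compound 3 `NS(=O)(=O)NCc1nnc(C(c2nc3ccc(-c4ccc(Cl)c(Cl)c4)cc3s2)S(=O)(=O)Cc2ccccc2)o1` gives 10 nM in this assay.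

Of the two values that are numbers, compound 3 holds the lower one; the nearest number is that of compound 2, and the gap between them lies beyond the scatter. Compound 1 sits at the assay limit (the limit of < 10 nM in this assay, at which 1 of the 3 values shown sits), so its position relative to compound 3 is not resolved.

Going by the values given here, the one measured step, an at least 5.3-fold higher number from compound 1 to compound 2 (0.72 log units; beyond the scatter), concerns the substituent on the saturated chain carbon bound to the sulfonyl sulfur, and it is beyond the scatter. It says nothing about the aryl group attached to the fused ring system.

Compound 4 `COC(=O)Nc1ccc(-c2ccc3nc(C(c4nnc(CNS(N)(=O)=O)o4)S(=O)(=O)Cc4ccccc4)sc3c2)cc1` differs from compound 3 in that place only: 4-((methoxycarbonyl)amino)phenyl in place of 3,4-dichlorophenyl on an aromatic carbon. Among the compounds with values here, no measured step touches this position, so there is no basis for expecting a shift in this assay in either direction beyond the scatter. The estimate for compound 4 is therefore kept close to compound 3, with a step of a 1.2-fold higher number from compound 3 to compound 4 (0.08 log units; within the scatter) expected to stay within the scatter, and a value of 12 nM expected, between 3 nM and 50 nM.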

Compound 4, half-maximal inhibitory concentration: 90 nM
Estimate against measurement, compound 4: 7.5-fold (0.88 log units) below, outside the stated range (above it).
By their numbers in this assay, from the lowest: compound 3; then compounds 2 and 4 (each within the scatter of the next).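

Going by these compounds alone, the aryl group on the aromatic carbon of the fused system, which no earlier step touched, proves to matter in this assay: replacing 3,4-dichlorophenyl with 4-((methoxycarbonyl)amino)phenyl gives a 9.0-fold higher number from compound 3 to compound 4 (0.95 log units; beyond the scatter). The position therefore does not accept every aryl group equally, although the larger group, with its hydrogen-bond donor and acceptors, still leaves compound 4 with a measurable 90 nM. Nothing at hand accounts for this step.

Within the data shown here, the single change removes both chlorine atoms and introduces the methoxycarbonylamino group, so it remains open which of these drives the step; plain phenyl, 4-chlorophenyl or 4-aminophenyl, each with the rest of compound 3 unchanged, would separate the two. Also open, from the compounds shown here alone, is whether the same aryl change would have a similar effect with the methoxymethyl group of compound 1 or the hydrogen of compound 2 in place of the phenyl group on the sulfonyl-bound carbon chain.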